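Amide tail change on the proline-linked series

A few compounds are considered here, and "the series" means these few. Any claim that something is new, unique, unknown or untested is made for them only; others in the source may bear on it.

Working notes. Of the compounds shown here, three have been tested in an assay on isolated protein for inhibition of tyrosine-protein kinase ZAP-70 (Homo sapiens), read by HTRF, tested at 10 uM; on this read-out higher numbers stand for more inhibition at the one concentration tested (going by the name of the read-out) and lower numbers for less inhibition. Compound 1 `Cc1cccc(Oc2ccnc(N3CCC[C@H]3C(=O)NCc3cccnc3)n2)c1` gives 6%, compound 3 `Cc1cccc(Nc2nccc3c2CN(C(=O)c2cc(C)n(C)c2C)CC3)c1` gives 4%, and compound 2 `CN(CCCn1ccnc1)C(=O)[C@@H]1CCCN1c1nccc(Nc2ccccc2)n1` gives 3%. The three numbers lie within the usual scatter of one another, so compound 2 cannot be set apart from compound 1 or compound 3 on this read-out. Compound 4 `CN(C)CC(C)(C)CNC(=O)[C@@H]1CCCN1c1nccc(Nc2ccccc2)n1` is not yet measured. It differs from compound 2 in one place: (2-((dimethylamino)methyl)-2-methylpropyl)amino in place of (3-(1H-imidazol-1-yl)propyl)(methyl)amino on a carbonyl carbon. Among the compounds with values here, no step between two measured compounds is available to guide the change, so the expectation rests on compound 2 at 3%. The step from compound 2 to compound 4 is expected to be a number 2 percentage points higher from compound 2 to compound 4 (within the scatter), none beyond the scatter. Compound 4 is estimated at 5% in this assay, with a range from -5% to 15%.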

Compound 4, a percentage reported as inhibition, at one concentration (the size of the read-out at that concentration, not a potency): 1%
Beside the measured number, compound 4's estimate is 4 percentage points above it; measured number inside the range.
By their numbers in this assay, from the lowest: compounds 4, 2, 3 and 1 (each within the scatter of the next).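

In this assay, (2-((dimethylamino)methyl)-2-methylpropyl)amino in place of (3-(1H-imidazol-1-yl)propyl)(methyl)amino on this carbonyl carbon gives a number 2 percentage points lower from compound 2 to compound 4 (within the scatter). This first one-place step shows that the two tails cannot be told apart on this read-out, although the five-membered aromatic ring leaves and an amide hydrogen enters. No available evidence bears on this result.

As far as these compounds go, whether a tail ending in a carboxylic acid or a morpholine on this carbonyl carbon would move the number beyond the scatter remains open. From the compounds shown here alone, the effect of changing the anilino group on the shared core also remains open.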